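The source may report more compounds than this note shows. Statements on the series, on what has been measured and on what is new or still open speak of the compounds shown alone.

For the measured compounds named here, only two compounds have been measured so far in a functional assay on MDA-MB-468 cells (Homo sapiens) for cytotoxicity, read by MTT assay, with a stated time of 96 h; a lower number here means a stronger inhibitor, a higher number a weaker inhibitor. Compound 1 `N=C(N)c1ccc(-c2ccc(-c3ccc([N+](=O)[O-])cc3)o2)cc1` gives 3400 nM, and compound 2 `N=C(N)c1ccc(-c2ccc(-c3cccc([N+](=O)[O-])c3)o2)cc1` gives 3300 nM. These two values lie within the scatter of each other, so compound 1 cannot be ranked apart from compound 2, and the data offer no wider range of values against which to place it.

Compound 3 `N=C(N)c1ccc(-c2ccc(-c3ccc(Br)cc3)o2)cc1` has not yet been measured. It carries bromo in place of nitro on an aromatic carbon of a six-membered aromatic ring of carbon only, para to a large group: bromo in place of nitro on an aromatic carbon. Going by the values given here, no measured step shows what this exchange does, so the expectation rests on compound 1 at 3400 nM as its starting point. Only a modest change is expected in this assay, leaning slightly toward a lower number and quite possibly not beyond the scatter. The estimated change is a 1.4-fold lower number from compound 1 to compound 3 (0.13 log units; within the scatter). For compound 3 the expected value is 2500 nM, with an estimated range from 900 nM to 7000 nM.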

Compound 3, half-maximal inhibitory concentration: 2500 nM
The estimate for compound 3 equals the measured number at the digits printed; the measured number falls inside the stated range.
By their numbers in this assay, from the lowest: compounds 3, 2 and 1 (each within the scatter of the next).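

In this assay, putting bromo in place of nitro on an aromatic carbon, para to a large group, gives a 1.4-fold lower number from compound 1 to compound 3 (0.13 log units; within the scatter). Compounds 1 and 2 both carry nitro and so could not show what happens when that group leaves; this step shows that nitro, with its 3 heavy atoms and 2 hydrogen-bond acceptors, can be replaced here by a single bromine atom with 0 hydrogen-bond acceptors without a change that stands clear of the scatter. No measurement of any property of these compounds is available to bear on this result.

For the compounds shown here, whether an amine, a carboxylic acid or a methoxy group on this same carbon would move the number beyond the scatter remains open, as nitro and bromo are the only two groups compared here. Also open, as far as these compounds go, is whether bromo on the carbon that holds the nitro group in compound 2 would give a similar number, and whether any group at either place can separate these compounds in this assay.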